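Swapping the Allyl Arm for a Cyanobenzyl Arm

The source may hold more compounds than are shown below. What is called first, only, known or untested is meant among the compounds shown, and "the series" means these compounds.

Measured compounds:
compound 1, `C=CCN1C(=O)C(=O)c2cc(-c3ccc(OC)cc3)ccc21`: 7090 nM
compound 2, `COc1ccc(-c2ccc3c(c2)C(=O)C(=O)N3Cc2ccc(Cl)c(Cl)c2)cc1`: 990 nM
compound 3, `COc1ccc(-c2ccc3c(c2)C(=O)C(=O)N3Cc2ccc(Br)cc2)cc1`: 700 nM

In a functional assay on HepG2 cells (Homo sapiens) for antiproliferative activity, read by MTT assay, with a stated time of 48 h (a higher number here means a weaker inhibitor, a lower number a stronger inhibitor), compound 1 stands at the highest number of the three, so it is the weakest inhibitor shown. Compound 4, `COc1ccc(-c2ccc3c(c2)C(=O)C(=O)N3Cc2ccc(C#N)cc2)cc1`, differs from compound 1 by 4-cyanophenyl in place of vinyl on a saturated chain carbon bound to an amide-type nitrogen in a ring. For the measured compounds named here, two measured steps bear on this: a 7.2-fold lower number from compound 1 to compound 2 (0.86 log units; beyond the scatter) and a 10-fold lower number from compound 1 to compound 3 (1.01 log units; beyond the scatter), each also placing a substituted phenyl where the vinyl was. The step of a 1.4-fold lower number from compound 2 to compound 3 (0.15 log units; within the scatter) shows that which substituent the phenyl carries matters little here, as those two values lie within the scatter of each other. A step of similar size toward a lower number is therefore expected for compound 4. Compound 4 is estimated at 900 nM, within a range of 400 nM to 2500 nM, which means an expected step of a 7.9-fold lower number from compound 1 to compound 4 (0.90 log units; beyond the scatter).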

Compound 4, half-maximal inhibitory concentration: 1000 nM
Compound 4: middle estimate off by 1.1-fold (0.05 log units), on the low side; the measured number falls inside the stated range.
By their numbers in this assay, from the lowest: compounds 3, 2 and 4 (each within the scatter of the next); then compound 1.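

The third substituted benzyl arm keeps the advantage over the allyl arm, with a 7.1-fold lower number from compound 1 to compound 4 (0.85 log units; beyond the scatter). Cyano in place of bromo gives a 1.4-fold higher number from compound 3 to compound 4 (0.15 log units; within the scatter), and 4-cyanophenyl in place of 3,4-dichlorophenyl gives a 1.0-fold higher number from compound 2 to compound 4 (0.00 log units; within the scatter), so a nitrile and halogens on this ring cannot be told apart by these numbers. No measurement shown explains this pattern.

Still open, on these data alone, is whether a plain benzyl arm, with nothing on its ring, would perform as well. A benzyl arm carrying an amine or a carboxylic acid, or a longer chain ending in the same ring, also remains to be seen.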